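A Chloro Substituent Enters the Phenyl Ring of Compound 3

The source may report more compounds than this note shows. Statements on the series, on what has been measured and on what is new or still open speak of the compounds shown alone.

Compound 3 `Cc1cccc(NC(=O)CN2CCC(c3ccccc3)CC2)c1` stands lowest of the three measured, at 135 nM in an assay on cells for antagonist activity at D(4) dopamine receptor (Homo sapiens), read by luminescence and beta-arrestin recruitment, with a stated time of 90 min; on this read-out higher numbers stand for weaker inhibition and lower numbers for stronger inhibition. Compound 1 `Cc1ccc(C2CCN(CC(=O)Nc3cccc(C)c3)CC2)nc1` gives 394 nM and compound 2 `Cc1ccc(C2CCN(CC(=O)Nc3cccc(C)c3)CC2)cc1` gives 7350 nM, so the two steps down to compound 3 were a 2.9-fold lower number from compound 1 to compound 3 (0.47 log units; beyond the scatter) and a 54-fold lower number from compound 2 to compound 3 (1.74 log units; beyond the scatter). Compound 4 `Cc1cccc(NC(=O)CN2CCC(c3ccc(Cl)cc3)CC2)c1` differs from compound 3 by chloro in place of hydrogen on an aromatic carbon, on an aromatic carbon of a six-membered aromatic ring of carbon only, para to a large group. The step that bears on this is a 54-fold lower number from compound 2 to compound 3 (1.74 log units; beyond the scatter), which shows a methyl at the place where chloro now enters weakened inhibition markedly. A weakening is expected again, estimated as a 5.2-fold higher number from compound 3 to compound 4 (0.71 log units; beyond the scatter). Compound 4 is expected to give 700 nM in this assay, within 200 nM to 3000 nM.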

Compound 4, half-maximal inhibitory concentration: 42400 nM
Beside the measured number, compound 4's estimate is 61-fold (1.78 log units) below it; the measured number lies above the stated range.
By their numbers in this assay, from the lowest: compound 3; then compound 1; then compound 2; then compound 4.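

In this assay, chloro in place of hydrogen on this aromatic carbon, para to a large group, gives a 310-fold higher number from compound 3 to compound 4 (2.50 log units; beyond the scatter), and chloro in place of methyl at the same carbon gives a 5.8-fold higher number from compound 2 to compound 4 (0.76 log units; beyond the scatter). Both groups therefore weaken inhibition here, chloro more so than methyl. The 4-chlorophenyl group also falls well behind 5-methylpyridin-2-yl, with a 110-fold higher number from compound 1 to compound 4 (2.03 log units; beyond the scatter). Nothing available accounts for the size of these steps. The compounds shown leave open how fluoro, methoxy or an amine at this carbon would compare with hydrogen.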